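A few compounds are considered here, and "the series" means these few. Any claim that something is new, unique, unknown or untested is made for them only; others in the source may bear on it.

Numbers in a functional assay on B16-F10 cells (Mus musculus) for cytotoxicity, read by CCK-8 assay, with a stated time of 48 h (on this read-out lower numbers stand for stronger inhibition and higher numbers for weaker inhibition), for the measured members of the series:
compound 1 `NS(=O)(=O)c1ccc(/N=C/c2c(Cl)c3ccccc3oc2=O)cc1` gives 300 nM;
compound 2 `O=c1oc2ccccc2c(Cl)c1/C=N/c1ccc(S(=O)(=O)Nc2nccs2)cc1` gives 300 nM;
compound 3 `N=C(N)NS(=O)(=O)c1ccc(/N=C/c2c(Cl)c3ccccc3oc2=O)cc1` gives 180 nM.

Compound 3 holds the lowest of the three numbers, but its separation from the other two is small: a 1.7-fold lower number from compound 1 to compound 3 (0.22 log units; within the scatter), and a 1.7-fold lower number from compound 2 to compound 3 (0.22 log units; within the scatter), both within the scatter. Compound 4 `Cc1cc(C)nc(NS(=O)(=O)c2ccc(/N=C/c3c(Cl)c4ccccc4oc3=O)cc2)n1` is obtained from compound 3 by the change (a group of 8 heavy atoms (6 carbon, 2 nitrogen; one six-membered aromatic ring with 2 hetero atoms) in place of a group of 3 heavy atoms (1 carbon, 2 nitrogen; no ring), on a sulfonamide nitrogen). Among the measured compounds shown here, two measured steps bear on this. The nearest is the reverse of the step in which the 1,3-thiazol-2-yl group on the sulfonamide nitrogen gave way to the 3-heavy-atom group now leaving: a 1.7-fold lower number from compound 2 to compound 3 (0.22 log units; within the scatter). The other, no change at the digits printed from compound 1 to compound 2 (within the scatter), shows that putting a five-membered aromatic ring with 2 hetero atoms on that nitrogen in place of hydrogen left the number unchanged. Across these three compounds no substituent on the sulfonamide nitrogen has moved this assay beyond the scatter. For compound 4 the expected step is therefore none beyond the scatter in either direction, a 1.4-fold higher number from compound 3 to compound 4 (0.14 log units; within the scatter). Compound 4 is estimated at 250 nM, with a range of 120 nM to 550 nM.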

Compound 4, half-maximal inhibitory concentration: 170 nM
Compound 4: middle estimate off by 1.5-fold (0.17 log units), on the high side; measured number inside the range.
By their numbers in this assay, from the lowest: compounds 4, 3, 1 and 2 (each within the scatter of the next).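

On the sulfonamide nitrogen, the series now includes a six-membered aromatic ring with 2 hetero atoms, and in this assay 4,6-dimethylpyrimidin-2-yl stays within the scatter of the 3-heavy-atom group (a 1.1-fold lower number from compound 3 to compound 4 (0.02 log units; within the scatter)), of 1,3-thiazol-2-yl (a 1.8-fold lower number from compound 2 to compound 4 (0.25 log units; within the scatter)) and of hydrogen (a 1.8-fold lower number from compound 1 to compound 4 (0.25 log units; within the scatter)). The tolerated range at this position therefore widens to a group of 8 heavy atoms with 0 hydrogen-bond donors, so neither the ring size nor the donor count of the four substituents separates the compounds beyond the scatter in this read-out. No measurement is available that would explain this flat response.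

All four compounds share the same core and differ only on the sulfonamide nitrogen, so the compounds shown say nothing about how changes elsewhere in the core affect the number. From the compounds shown here alone, it also remains open whether a carboxylic acid, a primary amine or a longer alkyl chain on the sulfonamide nitrogen would move the number beyond the scatter, or whether this position stays as flat with such groups as it has with the four substituents seen so far.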